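This account rests on a few compounds, and the source may have more. Where it says the series, first, only, none or still open, it means among the compounds named here.

Of the compounds shown here, three built on one shared core have been tested in an assay on isolated protein for inhibition of complement C1r subcomponent (Homo sapiens); on this read-out lower numbers stand for stronger inhibition and higher numbers for weaker inhibition. Compound 1 `O=c1oc(-c2ccccc2C(F)(F)F)nc2ccccc12` carries a trifluoromethyl group on its pendant ring. For compound 1 the assay reports only a limit, > 62500 nM, so no number is known for it; this is the limit of > 62500 nM in this assay, at which 1 of the 3 values shown sits. Compound 2 `O=c1oc(-c2ccccc2I)nc2cccc(Cl)c12` and compound 3 `O=c1oc(-c2ccccc2I)nc2ccc(Cl)cc12` both carry an iodo group on the pendant ring and differ only in where a chloro group sits on the fused ring system. In this assay compound 2 gives 57000 nM and compound 3 gives 27300 nM. Of the two numbers shown, compound 3 has the lower one, and its gap to compound 2 lies beyond the usual scatter, so compound 3 is the stronger of the two measured compounds. Compound 4 `O=c1oc(-c2ccccc2I)nc2cc(Cl)c(Cl)cc12` has not yet been measured and differs from compound 3 in one place: chloro in place of hydrogen on an aromatic carbon. Going by the values given here, no measured pair in this set makes this kind of change, so the expectation rests on compound 3 alone, and in this assay a step that is small, downward if anything, is expected. Compound 4 is estimated to give about 20000 nM, within a range from 6000 nM to 60000 nM. That estimate corresponds to a step of a 1.4-fold lower number from compound 3 to compound 4 (0.14 log units; within the scatter), expected to stay within the scatter.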

Compound 4, half-maximal inhibitory concentration: > 62500 nM
Compound 4 ended at the assay's limit; the forecaster's own chance of this, stated with the estimate: 10%; at least 3.1-fold (0.49 log units) between middle value and limit.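

In this assay, adding a chloro group to compound 3 does not leave inhibition unchanged or improve it: the change gives an at least 2.2-fold higher number from compound 3 to compound 4 (0.35 log units; beyond the scatter). Going by these compounds alone, this is the first single-place step in the set, and it shows that this aromatic carbon, ortho to a chloro group and para to a fused ring, does not freely accept a chloro group in place of hydrogen. Compound 4 gives only a limit, > 62500 nM, so the full size of its loss of inhibition remains unknown: the limit of > 62500 nM in this assay, at which 2 of the 4 values shown sit.

The compounds shown leave open how other groups at this position, such as fluoro, methoxy or an amine, would behave, as only hydrogen and chloro appear there. They also leave open whether the loss comes from a chloro group at this position alone or depends on the second chloro group already present in compound 3, which a compound carrying only the new chloro group could help to separate.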